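The compounds below may be only part of what the source reports. "The series", "measured", "known", "first", "only" and "open" are said of these compounds alone.

Two compounds of this series have been examined in a functional assay on SNB-75 cells (Homo sapiens) for inhibition, read by sulforhodamine B assay, with a stated time of 48 h, tested at 1 uM; a higher number here means a weaker effect of the compound at the concentration tested, a lower number a stronger effect. Compound 1, `O=C(Nc1cccc(-n2cc(-c3ccncc3)c(-c3cc(O)cc(Cl)c3)n2)c1)Nc1ccc(Cl)c(Cl)c1`, gives 63% there, and compound 2, `COc1cc(Cl)cc(-c2nn(-c3cccc(NC(=O)Nc4ccc(Cl)c(C(F)(F)F)c4)c3)cc2-c2ccncc2)c1`, gives 68%; the two readings lie within the scatter of each other, so neither can be set apart from the other. Compound 3, `COc1cc(Cl)cc(-c2nn(-c3cccc(NC(=O)Nc4ccc(Cl)c(Cl)c4)c3)cc2-c2ccncc2)c1`, has not yet been measured in this assay. It differs from compound 2 in one place: chloro in place of trifluoromethyl on an aromatic carbon. Among the measured compounds shown here, compound 1 also carries a 3,4-dichlorophenyl group, but it differs from compound 2 elsewhere as well, so no single step for this change can be read from the measured pair. The change is expected to move the reading little, with the step from compound 2 to compound 3 estimated at a number 2 percentage points lower from compound 2 to compound 3 (within the scatter), not beyond the scatter. Compound 3 is accordingly expected to give about 66% in this assay, within a range of 50% to 82%.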

Compound 3, a percentage reported as activity, at one concentration (the size of the read-out at that concentration, not a potency): 71%
Beside the measured number, compound 3's estimate is 5 percentage points below it, and the stated range covers the measured number.
By their numbers in this assay, from the lowest: compounds 1, 2 and 3 (each within the scatter of the next).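

Chloro in place of trifluoromethyl, ortho to a chloro group and meta to a large group, reads in this assay as a number 3 percentage points higher from compound 2 to compound 3 (within the scatter) and so gives no reading that can be set apart at this position. Methyl in place of hydrogen on the oxygen on the aromatic ring can now be read as a single step, a number 8 percentage points higher from compound 1 to compound 3 (within the scatter) in this assay, so the two forms of that oxygen cannot be told apart in these compounds either. Nothing at hand gives a reason for either reading.

As far as these compounds go, whether an amine or a carboxylic acid at the position of the chloro group, or a longer chain on that oxygen, would give a step beyond the scatter stays open. The compounds shown also leave open whether either change would read the same at other concentrations or in other cells.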